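The source may report more compounds than this note shows. Statements on the series, on what has been measured and on what is new or still open speak of the compounds shown alone.

Measured so far:
compound 1 `COc1ccc(C(c2ccc(OC)cc2)N2CCN(C(=O)COc3ccc4ccccc4c3)CC2)cc1` — 25.6%
compound 2 `O=C(COc1ccc2ccccc2c1)N1CCN(C(c2ccc(Br)cc2)c2ccc(Br)cc2)CC1` — 30.2%

In a functional assay on PC-12 cells (Rattus norvegicus) for cytotoxicity, read by MTT assay, with a stated time of 24 h, tested at 10 uM (on this read-out lower numbers stand for a weaker effect and higher numbers for a stronger effect at the one concentration tested), compound 1 gives 25.6%. Compound 2 gives 30.2%, a gap to compound 1 that lies within the usual scatter, so the two are not told apart. Compound 3 `COc1ccc(C(c2ccc(OC)cc2)N2CCN(C(=O)COc3ccccc3C)CC2)cc1` has not yet been measured. Against compound 1 it shows (2-methylphenyl in place of naphthalen-2-yl on an oxygen on a saturated carbon). Going by the values given here, neither measured compound carries a change at this place, so no measured step speaks to it. The step of a number 2.6 percentage points lower from compound 1 to compound 3 (within the scatter) is expected to be small, not beyond the scatter, with no direction asserted. Compound 3 is expected to give 23%, in the range 10% to 38%.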

Compound 3, a percentage reported as activity, at one concentration (the size of the read-out at that concentration, not a potency): 21.2%
Beside the measured number, compound 3's estimate is 1.8 percentage points above it, and the stated range covers the measured number.
By their numbers in this assay, from the lowest: compounds 3, 1 and 2 (each within the scatter of the next).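

In this assay, replacing naphthalen-2-yl (10 heavy atoms, 2 aromatic rings) with 2-methylphenyl (7 heavy atoms, one aromatic ring) on an oxygen on a saturated carbon gives a number 4.4 percentage points lower from compound 1 to compound 3 (within the scatter). Going by these compounds alone, this single step is the first reading at this place, and it shows that the smaller group does not move the read-out beyond the scatter on the core of compound 1. Nothing available explains the size of this step.

On these data alone, whether an amine or a carboxylic acid at this place would give a step beyond the scatter remains open. As far as these compounds go, it is also open whether the same change behaves alike on the core of compound 2.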